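Three limits and an untested nitro substitution

This account rests on a few compounds, and the source may have more. Where it says the series, first, only, none or still open, it means among the compounds named here.

Measured compounds, in a functional assay on HeLa cells (Homo sapiens) for antiproliferative activity, with a stated time of 24 h; on this read-out higher numbers stand for weaker inhibition and lower numbers for stronger inhibition:
- compound 1, `Cc1ccccc1CN1CCc2c(sc(NC(=O)c3ccccc3Cl)c2C(N)=O)C1`: in this assay compound 1 reaches only the assay limit, > 50000 nM.
- compound 2, `NC(=O)c1c(NC(=O)c2ccccc2Cl)sc2c1CCN(Cc1ccc(Cl)cc1)C2`: in this assay compound 2 likewise stops at the limit, > 50000 nM.
- compound 3, `NC(=O)c1c(NC(=O)c2ccccc2)sc2c1CCN(C(=S)Nc1ccccc1Cl)C2`: in this assay compound 3 also gives no number, only the limit > 50000 nM.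

All three values sit at the limit of > 50000 nM in this assay, at which 3 of the 3 values shown sit, so compound 3 stands level with the other two and no ordering among them can be read. Within the data shown here, the one single-point step measured, a step that the two limits leave unreadable from compound 1 to compound 2, is left unreadable by the two limits around it.

Compound 4, `NC(=O)c1c(NC(=O)c2cccc([N+](=O)[O-])c2)sc2c1CCN(C(=S)Nc1ccccc1Cl)C2`, differs from compound 3 by nitro in place of hydrogen on an aromatic carbon. Among the measured compounds shown here, no measured step touches this part of the structure, and the only step recorded is itself unreadable, so nothing in the data points to a direction. For compound 4 in this assay the expected step is a step that the limit leaves unreadable from compound 3 to compound 4, with the likeliest outcome another limit. The estimate for compound 4 is 60000 nM, in the range 20000 nM to 200000 nM.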

Compound 4, half-maximal inhibitory concentration: 40300 nM
Estimate against measurement, compound 4: 1.5-fold (0.17 log units) above; the measured number falls inside the stated range.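

Among these compounds, the aromatic ring of the benzoyl group is the first place where a change yields a number rather than a limit: in this assay, phenyl to 3-nitrophenyl gives an at least 1.2-fold lower number from compound 3 to compound 4 (0.09 log units; that floor lies within the scatter). On these data alone, this is only a floor on the step, so the true size remains unknown, and the floor alone does not separate the two compounds. The only other step, between the two benzyl-substituted compounds, cannot be read, and compound 4 is the sole compound with a number, the others staying at a limit: the limit of > 50000 nM in this assay, at which 3 of the 4 values shown sit.

As far as these compounds go, whether the number depends on nitro itself remains open, as an amine, a carboxylic acid or a nitrile at the same place would be needed to test it. Also open, from the compounds shown here alone, is whether nitro at another place on this ring, or with a different group on the ring nitrogen of the shared core, would give a number.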